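From a Benzodioxin Sulfonamide to a Trifluoromethoxyphenyl Analogue

This account rests on a few compounds, and the source may have more. Where it says the series, first, only, none or still open, it means among the compounds named here.

Two compounds have been measured in a functional assay on CHO cells for antagonist activity at 5-hydroxytryptamine receptor 6 (Homo sapiens), read by FLIPR; a higher number here means a weaker inhibitor, a lower number a stronger inhibitor:
compound 1, `COc1ccc(S(=O)(=O)N2CC(C(=O)N(C)C3CCN(C)CC3)c3ccccc32)c2ccccc12`, gives 7.94 nM
compound 2, `CN1CCC(N(C)C(=O)C2CN(S(=O)(=O)c3ccc4c(c3)OCCO4)c3ccccc32)CC1`, gives 50.1 nM

Compound 2 holds the higher of the two numbers, and the gap to compound 1 lies beyond the usual scatter, so compound 2 is the weaker inhibitor of this pair. Both share the same core, a fused bicyclic sulfonamide carrying an amide to a methylpiperidine, and differ only in the aromatic group attached to the sulfonyl sulfur.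

Compound 3, `CN1CCC(N(C)C(=O)C2CN(S(=O)(=O)c3ccc(OC(F)(F)F)cc3)c3ccccc32)CC1`, has not yet been measured. It differs from compound 2 in one place: 4-(trifluoromethoxy)phenyl in place of 2,3-dihydro-1,4-benzodioxin-6-yl on a sulfonyl sulfur. Within the data shown here, no pair with exactly this change has been measured here, so the size of the step rests on judgement. The two measured compounds show that the group on the sulfonyl sulfur can shift this assay by a sizeable amount, so a step of similar or smaller size seems plausible, and a move toward a lower number appears somewhat more likely than a rise. Compound 3 is expected to give 30 nM, with a likely range from 8 nM to 120 nM, which means an expected step of a 1.7-fold lower number from compound 2 to compound 3 (0.22 log units; within the scatter).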

Compound 3, inhibition constant: 20 nM
The estimate for compound 3 lay 1.5-fold (0.18 log units) above the measured number; measured number inside the range.
By their numbers in this assay, from the lowest: compound 1; then compound 3; then compound 2.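

In this assay, exchanging the group on the sulfonyl sulfur gives a 2.5-fold lower number from compound 2 to compound 3 (0.40 log units; beyond the scatter), a modest step but one that lies beyond the usual scatter. This pair differs in one place only, so it ties a change in the number directly to the group on the sulfur, with the rest of the molecule held constant. The entering group keeps a six-membered aromatic ring but has no six-membered non-aromatic ring, and this loss does not cost inhibition in this pair, although nothing shown gives a cause for the shift.

The compounds shown cannot separate the contribution of the trifluoromethoxy group from that of removing the non-aromatic ring, and a plain phenyl or a 4-methoxyphenyl on the same sulfur would be the natural way to pull those two apart. Also open, as far as these compounds go, is how a group carrying an amine or a carboxylic acid would behave at this position, and whether the same step would appear with a different amide on the shared core.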